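Sulfonyl for carbamoyl on a shared core in K562 cells

A few compounds are considered here, and "the series" means these few. Any claim that something is new, unique, unknown or untested is made for them only; others in the source may bear on it.

Measured compounds:
Compound 1, `Cn1c(=O)c(S(=O)(=O)c2ccc(F)cc2F)cc2cnc(Nc3ccc4[nH]c(C(=O)O)cc4c3)nc21`, 10000 nM
Compound 2, `Cn1c(=O)c(C(=O)Nc2ccc(F)cc2)cc2cnc(Nc3ccc4[nH]ccc4c3)nc21`, 5000 nM

Of the compounds shown here, two have been tested in a functional assay on K562 cells (Homo sapiens) for inhibition, read by trypan blue exclusion, with a stated time of 72 h; a lower number here means a stronger inhibitor, a higher number a weaker inhibitor. Compound 2 holds the lower of the two numbers, at 5000 nM, while compound 1 gives 10000 nM; the gap between them is within the usual scatter, so neither compound can be called the stronger inhibitor on this evidence. For the measured compounds named here, compound 1 and compound 2 differ in more than one place, and no single step between them is available.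

Compound 3, `Cn1c(=O)c(S(=O)(=O)c2ccc(N)cc2F)cc2cnc(Nc3ccc4[nH]ccc4c3)nc21`, has not yet been measured in this assay. It differs from compound 2 in one place: (4-amino-2-fluorophenyl)sulfonyl in place of (4-fluorophenyl)carbamoyl on an aromatic carbon. The change thus replaces a carbamoyl linker bearing a fluorophenyl with a sulfonyl linker bearing an amino-fluorophenyl, while the rest of compound 2 is kept.

Going by the values given here, with no measured step of the same kind to rest on, the expectation for compound 3 is that the number moves, if at all, by a modest amount, and a shift beyond the scatter in either direction would not surprise. The estimated step of a 1.7-fold lower number from compound 2 to compound 3 (0.22 log units; within the scatter) is small. Compound 3 is expected to give about 3000 nM in this assay, within a range of 700 nM to 12000 nM.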

Compound 3, half-maximal inhibitory concentration: 1500 nM
Compound 3: middle estimate off by 2.0-fold (0.30 log units), on the high side, within the range that was stated.
By their numbers in this assay, from the lowest: compound 3; then compounds 2 and 1 (each within the scatter of the next).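

In this assay, for the compounds shown here, placing (4-amino-2-fluorophenyl)sulfonyl where (4-fluorophenyl)carbamoyl stood gives a 3.3-fold lower number from compound 2 to compound 3 (0.52 log units; beyond the scatter), the only single-place step available so far, and it shows that the number responds to the group carried on this aromatic carbon, ortho to a group of one heavy atom and two atoms from the ring nitrogen. The exchange alters several things at once: the linker passes from carbamoyl to sulfonyl, the ring gains an amine and its fluorine differs in place, and the count of hydrogen-bond acceptors goes from 1 to 3 while the count of donors stays at 1, so the step belongs to the whole group and to none of these parts alone. Nothing at hand accounts for the size of this step.

The compounds shown leave open how much of the step follows the sulfonyl linker and how much follows the amine, a question that a carbamoyl linker carrying the same 4-amino-2-fluorophenyl ring would address. They also leave open whether a hydroxyl or a methoxy group in the place of the amine would hold the number at this level.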